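The source may hold more compounds than are shown below. What is called first, only, known or untested is meant among the compounds shown, and "the series" means these compounds.

Working notes on the series, read in a functional assay on the whole organism with Scenedesmus acutus as the target; on this read-out higher numbers stand for weaker inhibition and lower numbers for stronger inhibition. Compound 1 `O=C(O)c1cc(N2C(=O)C3=C(CCCC3)C2=O)c(F)cc1Cl` gives 759 nM, within the scatter of compound 3 `CCOC(=O)c1cc(N2C(=O)C3=C(CCCC3)C2=O)ccc1Cl` at 1380 nM. Compound 2 `O=C(O)c1cc(N2C(=O)C3=C(CCCC3)C2=O)ccc1Cl` reads > 100000 nM, which is a limit of the assay. Compound 4 `CC(C)OC(=O)c1cc(N2C(=O)C3=C(CCCC3)C2=O)c(F)cc1Cl` departs from compound 1 by isopropyl in place of hydrogen on an oxygen next to a carbonyl group, with isopropyl in place of hydrogen on an oxygen next to a carbonyl group. The closest measured change is ethyl for that same hydrogen, an at least 72-fold lower number from compound 2 to compound 3 (1.86 log units; beyond the scatter), seen only without the fluoro group. Restoring fluoro alone gave the step of an at least 130-fold higher number from compound 1 to compound 2 (2.11 log units; beyond the scatter) in reverse. Both steps start from or end at the limit, so their sizes carry over only loosely. A moderate to large move towards a lower number, beyond the scatter, is expected. Compound 4 is estimated at 60 nM, with an expected range of 6 nM to 600 nM. The estimate means a 13-fold lower number from compound 1 to compound 4 (1.10 log units; beyond the scatter).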

Compound 4, half-maximal inhibitory concentration: 57.5 nM
Compound 4: middle estimate off by 1.0-fold (0.02 log units), on the high side; the measured number falls inside the stated range.
By their numbers in this assay, from the lowest: compound 4; then compounds 1 and 3 (each within the scatter of the next). At a limit, above all of these: compound 2.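

In this assay, isopropyl in place of hydrogen on an oxygen next to a carbonyl group gives a 13-fold lower number from compound 1 to compound 4 (1.12 log units; beyond the scatter) and so sizes this change between two measured numbers, with the fluoro group present. The earlier step on this oxygen began at compound 2, whose value is a limit: the limit of > 100000 nM in this assay, at which 1 of the 4 values shown sits. Compounds 3 and 4 differ in two places, so ethyl and isopropyl cannot be ranked against each other here. On these data alone, whether a longer chain such as butyl on the same oxygen, or an amide in place of the ester, would give a lower number remains open.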